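Adding a hydroxy to a poorly soluble amide

The compounds below may be only part of what the source reports. "The series", "measured", "known", "first", "only" and "open" are said of these compounds alone.

Measured so far in a physicochemical assay for solubility, read by nephelometry, measured as kinetic solubility, at pH 2.0; a higher number here means a more soluble compound, a lower number a less soluble compound
- compound 1 `CC(C)(C)c1cc(C(=O)Nc2cccc(CN)c2)n(Cc2ccccc2)n1` gives > 100 ug/mL as a limit of the assay
- compound 2 `Cc1csc(NC(=O)c2cc(C(C)(C)C)nn2Cc2ccccc2)n1` gives < 1.6 ug/mL as a limit of the assay

Compound 2 gives < 1.6 ug/mL and this is a limit of the assay, not a number. Among the measured compounds shown here, the one measured step is an at least 62-fold lower number from compound 1 to compound 2 (1.79 log units; beyond the scatter) and it is large and beyond the scatter. It came with 4-methyl-1,3-thiazol-2-yl in place of 3-(aminomethyl)phenyl on an amide-type nitrogen.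

Compound 3 `CC(C)(C)c1cc(C(=O)Nc2nc(CO)cs2)n(Cc2ccccc2)n1` keeps the rest of compound 2 and carries hydroxy in place of hydrogen on a saturated chain carbon bound to an aromatic carbon, which turns methyl to hydroxymethyl. For the measured compounds named here, no measured step covers this exact change. The change in an at least 62-fold lower number from compound 1 to compound 2 (1.79 log units; beyond the scatter) swapped a whole group, so it shows only that this read-out can move widely among these compounds. A much smaller move is therefore expected here, and upward. The expected step is an at least 2.5-fold higher number from compound 2 to compound 3 (0.39 log units; beyond the scatter) and it remains an estimate. For compound 3 the estimated value is 4 ug/mL (range 1 ug/mL to 20 ug/mL).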

Compound 3, solubility: 12.5 ug/mL
The estimate for compound 3 lay 3.1-fold (0.49 log units) below the measured number, and the stated range covers the measured number.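

In this assay, among the compounds shown here, the step of an at least 7.8-fold higher number from compound 2 to compound 3 (0.89 log units; beyond the scatter) is the first reading of a single small change on this series: hydroxy in place of hydrogen on a saturated chain carbon bound to an aromatic carbon, with the rest of the molecule kept. The earlier pair swapped a whole group, so it could not show that this one place, with methyl turned to hydroxymethyl, can carry a move beyond the scatter by itself. The size of that move has only a floor, since compound 2 stands at a limit of the assay and not at a number: the limit of < 1.6 ug/mL in this assay, at which 1 of the 3 values shown sits.

Even with the hydroxy in place, 4-(hydroxymethyl)-1,3-thiazol-2-yl does not match 3-(aminomethyl)phenyl on the amide nitrogen, as the step of an at least 8.0-fold lower number from compound 1 to compound 3 (0.90 log units; beyond the scatter) shows, and how wide that gap really is stays open, since compound 1 also stands at a limit of the assay: the limit of > 100 ug/mL in this assay, at which 1 of the 3 values shown sits. Also open is whether an amine, a carboxylic acid or a longer chain in the same place on the 4-methyl-1,3-thiazol-2-yl group would move this read-out further than hydroxy did.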